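The compounds below may be only part of what the source reports. "The series", "measured", "known", "first", "only" and "open" are said of these compounds alone.

Measured so far:
- compound 1 `O=C(Nc1ccc(Sc2nc3ccccc3s2)c(Cl)c1)c1cccc(Br)c1O`: 68000 nM
- compound 2 `COc1c(Br)cccc1C(=O)Nc1ccc(Sc2nc3ccccc3s2)cc1`: > 100000 nM

The read-out throughout is an ADME assay on HEK293 cells (Homo sapiens) for cytotoxicity, read by resazurin assay, with a stated time of 48 h; a lower number here means that less compound is tolerated, a higher number that more compound is tolerated. In this assay compound 2 gives > 100000 nM, which is a limit of the assay and not a number. Compound 2 therefore stands at the limit of > 100000 nM in this assay, at which 1 of the 2 values shown sits. Compound 1 gives a true number in the same assay, 68000 nM.

The next compound is compound 3 `COc1c(Br)cccc1C(=O)Nc1ccc(Sc2nc3ccccc3s2)c(Cl)c1`, which carries chloro in place of hydrogen on an aromatic carbon of compound 2: chloro in place of hydrogen on an aromatic carbon.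

Among the measured compounds shown here, no measured step covers this change, so the expectation rests on little. For the measured compounds named here, it leans on compound 1, at 68000 nM, as the only number available in this assay. A modest fall in the tolerated concentration is expected, not far beyond the scatter, and a second report as a limit remains quite possible. The expected change is an at least 1.2-fold lower number from compound 2 to compound 3 (0.09 log units; that floor lies within the scatter). For compound 3 the estimated value is 80000 nM, with an expected range of 40000 nM to 120000 nM.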

Compound 3, half-maximal cytotoxic concentration: 40000 nM
The estimate for compound 3 lay 2.0-fold (0.30 log units) above the measured number, and the stated range covers the measured number.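

In this assay, among the compounds shown here, chloro in place of hydrogen on an aromatic carbon, ortho to a large group and meta to a large group, gives an at least 2.5-fold lower number from compound 2 to compound 3 (0.39 log units; beyond the scatter) and is the first step beyond the scatter. The other new comparison, methyl in place of hydrogen on an oxygen on an aromatic ring, gives a 1.7-fold lower number from compound 1 to compound 3 (0.23 log units; within the scatter) and stays within the scatter, so with chloro present the two forms of that oxygen do not separate in this read-out. Compound 2 is a limit of the assay and not a number, so the chloro step has a floor and no true size: the limit of > 100000 nM in this assay, at which 1 of the 3 values shown sits.

From the compounds shown here alone, whether this fall in the tolerated concentration belongs to chloro alone stays open, and a fluoro, a methyl or an amine on the same aromatic carbon would test that. Also open, going by these compounds, is whether the oxygen change stays within the scatter without chloro, and whether a carboxylic acid in place of the bromo group would shift the tolerated concentration on the same core.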